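The source may hold more compounds than are shown below. What is called first, only, known or untested is meant among the compounds shown, and "the series" means these compounds.

Of the compounds shown here, three built on one shared core have been tested in an ADME assay on HeLa cells (Homo sapiens) for cytotoxicity, read by ATP content, with a stated time of 3 days; a lower number here means that less compound is tolerated, a higher number that more compound is tolerated. Compound 1 `O=c1n(Cc2nc3nc(Cl)ccc3n2CCCCF)c2cnccc2n1C1CC1` reaches only the limit of the test, > 50000 nM. Compound 2 `COc1ccc(-n2c(=O)n(Cc3cc4cc(Cl)ccc4n3CCCC#N)c3cnccc32)cc1` likewise gives a limit, > 50000 nM. Compound 3 `COc1ccc(-n2c(=O)n(Cc3cc4cc(Cl)ccc4n3CCCC#N)c3cnccc32)c(F)c1` also stands at a limit, > 50000 nM, so its place among the three is known only as a bound. Within the data shown here, the step that the two limits leave unreadable from compound 2 to compound 3 therefore cannot be sized, and the limit of > 50000 nM in this assay, at which 3 of the 3 values shown sit, shows that every value so far sits at that bound. Compound 4 `CS(=O)(=O)c1ccc(-n2c(=O)n(Cc3cc4cc(Cl)ccc4n3CCCC#N)c3cnccc32)cc1` carries one change relative to compound 3: 4-(methylsulfonyl)phenyl in place of 2-fluoro-4-methoxyphenyl on an aromatic nitrogen. Among the measured compounds shown here, since no measured step reads out, no change beyond the scatter is expected. Compound 4 is estimated at 60000 nM, between 20000 nM and 200000 nM. The expected step is a step that the limit leaves unreadable from compound 3 to compound 4.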

Compound 4, half-maximal cytotoxic concentration: > 50000 nM
Compound 4 was reported as a limit; the forecaster's own chance of this, stated with the estimate: 85%; the middle value lies beyond the limit too.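

Compound 4 also stands at a limit, so the steps to it from compound 2 and from compound 3 cannot be read: the limit of > 50000 nM in this assay, at which 4 of the 4 values shown sit.

The compounds shown leave open whether any single change on the shared core alters the result in this assay.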